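Secondary Amine in Place of a Tertiary One

The source may report more compounds than this note shows. Statements on the series, on what has been measured and on what is new or still open speak of the compounds shown alone.

In a functional assay on BE(2)-C cells (Homo sapiens) for inhibition, read by MTT assay, with a stated time of 72 h (a lower number here means a stronger inhibitor of growth, a higher number a weaker inhibitor of growth), compound 1 `O=S(=O)(NCCCNCC1COc2ccccc2O1)c1cc(C(F)(F)F)cc(C(F)(F)F)c1` gives 2800 nM, while compound 2 `CN(CCCNS(=O)(=O)c1cc(C(F)(F)F)cc(C(F)(F)F)c1)Cc1ccccc1` gives 28000 nM, the higher of the two numbers, a gap beyond the scatter. Compound 3 `O=S(=O)(NCCCNCc1ccc(Br)cc1)c1cc(C(F)(F)F)cc(C(F)(F)F)c1` differs from compound 2 by (4-bromobenzyl)amino in place of benzyl(methyl)amino on a saturated chain carbon, three bonds along the chain from a sulfonamide nitrogen. Among the compounds with values here, no measured pair shows this kind of change, so the only guide is that the secondary amine of compound 1 sits at the lower number; on that basis compound 3 is expected to shift by a 6.2-fold lower number from compound 2 to compound 3 (0.79 log units; beyond the scatter), towards a lower number. In this assay compound 3 is estimated at 4500 nM, with a range from 1500 nM to 14000 nM.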

Compound 3, concentration for 50% growth inhibition: 2700 nM
The estimate for compound 3 lay 1.7-fold (0.22 log units) above the measured number; measured number inside the range.
By their numbers in this assay, from the lowest: compounds 3 and 1 (each within the scatter of the next); then compound 2.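

In this assay, the change at this position gives a 10-fold lower number from compound 2 to compound 3 (1.02 log units; beyond the scatter), a large step that adds one hydrogen-bond donor while the heavy-atom count stays the same. The step of a 1.0-fold lower number from compound 1 to compound 3 (0.02 log units; within the scatter) lies within the scatter, so 4-bromophenyl and 2,3-dihydro-1,4-benzodioxin-2-yl on this chain carbon cannot be told apart here. No evidence on the cause of either step is available. The first step combines the loss of the methyl with the gain of the bromine, and the compounds shown leave open which of them matters. A plain benzylamino group at this place would separate the two.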